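A few compounds are considered here, and "the series" means these few. Any claim that something is new, unique, unknown or untested is made for them only; others in the source may bear on it.

Working notes on the series.

Compound 1 `Oc1cccc(-c2cc(-c3cccs3)cc(-c3cccc(O)c3)n2)c1` is measured in an assay on isolated protein for inhibition of DNA topoisomerase 1 (Homo sapiens), with a stated time of 30 min, tested at 100 uM; on this read-out lower numbers stand for a weaker effect and higher numbers for a stronger effect at the one concentration tested; compound 1 gives 91.7%. Compound 2 `Oc1ccc(-c2cc(-c3cccs3)cc(-c3cccc(O)c3)n2)cc1` carries the change (4-hydroxyphenyl in place of 3-hydroxyphenyl on an aromatic carbon); in this assay compound 2 gives 85.7%, and the step is a number 6 percentage points lower from compound 1 to compound 2 (within the scatter). Compound 3 `Oc1cccc(-c2cc(-c3ccsc3)cc(-c3ccccc3O)n2)c1` has a different core; the difference between the two cores is not broken down here. In this assay compound 3 gives 10.2%, the lowest number of the three measured compounds, beyond the scatter from both others.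

Compound 4 `Oc1ccc(-c2cc(-c3ccsc3)cc(-c3ccccc3O)n2)cc1` is not yet measured. The change from compound 3 is 4-hydroxyphenyl in place of 3-hydroxyphenyl on an aromatic carbon, the same kind of change as from compound 1 to compound 2, though the surroundings differ: in compound 1 the place is meta to a 3-hydroxyphenyl group and meta to a thiophen-2-yl group, in compound 3 it is meta to a 2-hydroxyphenyl group and meta to a thiophen-3-yl group. The expected step is a number 2.2 percentage points lower from compound 3 to compound 4 (within the scatter), set beside a number 6 percentage points lower from compound 1 to compound 2 (within the scatter), because that earlier step was within the scatter and the low starting number of compound 3 10.2% leaves little room downward. The estimated value for compound 4 in this assay is 8%, expected between 0% and 30%.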

Compound 4, a percentage reported as inhibition, at one concentration (the size of the read-out at that concentration, not a potency): 13.8%
The estimate for compound 4 lay 5.8 percentage points below the measured number; the range from low to high includes it.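

In this assay, 4-hydroxyphenyl in place of 3-hydroxyphenyl gives a number 3.6 percentage points higher from compound 3 to compound 4 (within the scatter), so on this second core, as on the first, the swap produces no step beyond the scatter. The two cores agree on this change: the same change on two cores in this assay, a number 6 percentage points lower (within the scatter) from compound 1 to compound 2 and a number 3.6 percentage points higher (within the scatter) from compound 3 to compound 4, 9.6 percentage points apart, within the scatter of two such steps

Among the compounds shown here, this supports treating the swap as carrying over between these two cores, at the high read-out of compound 1 and at the low read-out of compound 3 alike, but it rests on only two pairs and does not show that the same would hold on any further core, nor does it say which difference between the cores goes with the gap in read-out.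

Every aryl group on the ring nitrogen's side shown here keeps a hydroxyl, so what a methoxy group, an amine or a carboxylic acid in that place would do remains open. Each number is the size of the effect at one concentration, so how strong the effect of these compounds would be at other concentrations also remains open.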